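Removing an ethoxy group from a weakly active screening hit

The compounds below may be only part of what the source reports. "The series", "measured", "known", "first", "only" and "open" are said of these compounds alone.

Compound 1 `CCOc1ccc(-c2nn3cc(-c4cccc(N)c4)nc3s2)cc1` carries an ethoxy group on one of its outer benzene rings and an amine on the other. In a functional assay on FM3A cells (Mus musculus) for inhibition, read by cell counting, with a stated time of 2 days (on this read-out lower numbers stand for stronger inhibition and higher numbers for weaker inhibition), compound 1 reaches only the assay limit of >= 250000 nM, so no number is known for it. The picture given by the limit of >= 250000 nM in this assay, at which 1 of the 3 values shown sits, is therefore one of a compound at the edge of what the test can report. Two other compounds share parts of this design. Compound 2 `Nc1cccc(-c2cn3c(-c4ccccc4)csc3n2)c1`, with a related core and the same amine-bearing ring, gives 34000 nM in this assay. Compound 3 `C=C(Br)C(=O)Nc1cccc(-c2cn3nc(-c4cccs4)sc3n2)c1`, with the bromoacrylamide in place of the free amine and a thiophene on the other side, gives 370 nM.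

Compound 4 `Nc1cccc(-c2cn3nc(-c4ccccc4)sc3n2)c1` is compound 1 with hydrogen in place of ethoxy on an aromatic carbon. For the measured compounds named here, no step between two measured compounds matches this change, and compound 1 itself offers only a limit, so the expected step of an at least 4.1-fold lower number from compound 1 to compound 4 (0.61 log units; beyond the scatter) from compound 1 to compound 4 rests on the limit alone and points toward a reportable number rather than a definite size. The estimate for compound 4 in this assay is 60000 nM, within a range from 8000 nM to 250000 nM.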

Compound 4, half-maximal inhibitory concentration: 14000 nM
Beside the measured number, compound 4's estimate is 4.3-fold (0.63 log units) above it; the measured number falls inside the stated range.
By their numbers in this assay, from the lowest: compound 3; then compound 4; then compound 2. At a limit, above all of these: compound 1.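

In this assay, for the compounds shown here, putting hydrogen in place of ethoxy on an aromatic carbon, para to a large group, gives an at least 17-fold lower number from compound 1 to compound 4 (1.25 log units; beyond the scatter), a large step and the first between two compounds that differ in one place. Going by these compounds alone, compound 1 and compound 4 share everything else, so this step belongs to that single swap, something the earlier compounds could not show because they differ from one another in more than one place: the ethoxy group on this ring carbon goes with a much weaker result than plain hydrogen does. The true size of the step stays unknown, and the printed figure is only a minimum, as compound 1 stands at a limit of the assay and not at a number: the limit of >= 250000 nM in this assay, at which 1 of the 4 values shown sits.

The compounds shown leave open whether a methoxy group or a single fluorine atom on this aromatic carbon would give a number nearer to that of compound 4 or to the limit of compound 1. Within the data shown here, they also leave open what the same swap does where a bromoacrylamide takes the place of the free amine, as compound 3, the only compound with that group, also carries a thiophene.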